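Swapping a Chain-End Carboxy for Pentyl on a Long Ether

The source may hold more compounds than are shown below. What is called first, only, known or untested is meant among the compounds shown, and "the series" means these compounds.

Compound 3 `O=C(O)CCCCCCCOc1ccc2c(=O)c(-c3ccc(O)cc3)coc2c1` gives 40 nM in an assay (Cricetulus griseus) for inhibition of aldehyde dehydrogenase, mitochondrial (Homo sapiens) (a higher number here means a weaker inhibitor, a lower number a stronger inhibitor), the lowest number among the three measured compounds. Compound 1 `CCOc1ccc2c(=O)c(-c3ccc(O)cc3)coc2c1` gives 80 nM, and a 2.0-fold lower number from compound 1 to compound 3 (0.30 log units; within the scatter). Compound 2 `O=c1c(-c2ccc(O)cc2)coc2cc(OCCCCCCCCCO)ccc12` gives 700 nM, and an 18-fold lower number from compound 2 to compound 3 (1.24 log units; beyond the scatter). Compound 4 `CCCCCCCCCCCCOc1ccc2c(=O)c(-c3ccc(O)cc3)coc2c1` is not yet measured; it differs from compound 3 by pentyl in place of carboxy on a saturated chain carbon, seven bonds along the chain from an oxygen on an aromatic ring. Going by the values given here, two measured steps bear on this change: the only step that introduces a carboxy at this chain end was large, as an 18-fold lower number from compound 2 to compound 3 (1.24 log units; beyond the scatter) shows, and a long chain carrying no carboxy gave an 8.8-fold higher number from compound 1 to compound 2 (0.94 log units; beyond the scatter). Removing the carboxy is therefore expected to raise the number, with an 8.8-fold higher number from compound 3 to compound 4 (0.94 log units; beyond the scatter). Compound 4 is expected to give 350 nM, between 80 nM and 1500 nM.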

Compound 4, half-maximal inhibitory concentration: > 9000 nM
Compound 4 was reported as a limit (the forecaster's own chance of this, stated with the estimate: 5%); middle value at least 25-fold (1.41 log units) from the limit.
By their numbers in this assay, from the lowest: compounds 3 and 1 (each within the scatter of the next); then compound 2. At a limit, above all of these: compound 4.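

Compound 4 is reported only as a limit of the assay, > 9000 nM, so every step to it is a limit too. Pentyl in place of carboxy gives an at least 220-fold higher number from compound 3 to compound 4 (2.35 log units; beyond the scatter), a far larger rise than the earlier steps suggested. Propyl in place of hydroxy still gives an at least 12-fold higher number from compound 2 to compound 4 (1.10 log units; beyond the scatter), and decyl in place of hydrogen gives an at least 110-fold higher number from compound 1 to compound 4 (2.05 log units; beyond the scatter), so among these compounds the long chain is tolerated only when it carries an oxygen group. As far as these compounds go, how a methyl ester, an amide or an amine would compare in this place remains open, as does a shorter chain carrying the carboxylic acid.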